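Series notes: furanyl in place of the dimethoxyphenyl ketone

The source may hold more compounds than are shown below. What is called first, only, known or untested is meant among the compounds shown, and "the series" means these compounds.

Of the compounds shown here, three have been measured in a functional assay on MCF7 cells (Homo sapiens) for antiproliferative activity, read by XTT assay, with a stated time of 72 h; a lower number here means a stronger inhibitor, a higher number a weaker inhibitor. Compound 1 `COc1ccc(-c2cc3ccccc3nc2/C=C/C(=O)c2ccc(OC)cc2OC)cc1` gives 6260 nM, compound 2 `COc1ccc(-c2cc3ccccc3nc2/C=C/C(=O)c2c(OC)cccc2OC)cc1` gives 4520 nM, and compound 3 `COc1ccc(-c2cc3ccccc3nc2/C=C/C(=O)c2ccc(OC)c(OC)c2)cc1` gives 6030 nM. Rearranging the methoxy groups on the dimethoxyphenyl at the carbonyl carbon changes little: a 1.4-fold lower number from compound 1 to compound 2 (0.14 log units; within the scatter), a 1.0-fold lower number from compound 1 to compound 3 (0.02 log units; within the scatter), a 1.3-fold higher number from compound 2 to compound 3 (0.13 log units; within the scatter). The number of compound 3 is the second highest of the three, nearest to compound 1 and furthest from compound 2, yet all three lie within the scatter of one another.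

Compound 4 `COc1ccc(-c2cc3ccccc3nc2/C=C/C(=O)c2ccco2)cc1` differs from compound 3 in one place: furan-2-yl in place of 3,4-dimethoxyphenyl on a carbonyl carbon. Among the measured compounds shown here, none of the measured steps exchanges the dimethoxyphenyl for another ring; they only move methoxy groups around on it, and every one of them stays within the scatter. They bear on the present change only indirectly, showing that this position has so far absorbed alteration without a shift beyond the scatter, but they say nothing about a five-membered aromatic ring with 1 hetero atom. The step expected in this assay is therefore none beyond the scatter, with wide uncertainty: a 1.0-fold lower number from compound 3 to compound 4 (0.00 log units; within the scatter). Compound 4 is estimated at 6000 nM, with a range from 2000 nM to 18000 nM.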

Compound 4, half-maximal inhibitory concentration: 710 nM
Beside the measured number, compound 4's estimate is 8.5-fold (0.93 log units) above it; the measured number lies below the stated range.
By their numbers in this assay, from the lowest: compound 4; then compounds 2, 3 and 1 (each within the scatter of the next).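

In this assay, replacing a dimethoxyphenyl with furan-2-yl on the carbonyl carbon gives the first shifts beyond the scatter at this position: an 8.5-fold lower number from compound 3 to compound 4 (0.93 log units; beyond the scatter), a 6.4-fold lower number from compound 2 to compound 4 (0.80 log units; beyond the scatter) and an 8.8-fold lower number from compound 1 to compound 4 (0.95 log units; beyond the scatter). The position therefore tolerates rearrangement of the methoxy groups without a measurable shift but responds when the ring itself is exchanged, and compound 4 is the strongest inhibitor of the four. No measurement at hand accounts for this shift.

The exchange removes the methoxy groups and introduces the five-membered aromatic ring in a single step, so the compounds shown do not separate these two changes. From the compounds shown here alone, whether an unsubstituted phenyl, a thiophene or a pyridine ring on the carbonyl carbon would give a number close to that of compound 4 remains open.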